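The compounds below may be only part of what the source reports. "The series", "measured", "known", "first", "only" and "open" are said of these compounds alone.

Three compounds built on one shared core were tested in a functional assay on Jurkat cells for inhibition of nuclear factor NF-kappa-B complex (Homo sapiens); a higher number here means a weaker inhibitor, a lower number a stronger inhibitor. Compound 1 `CCOC(=O)c1cnc(-c2ccc(OC)cc2)nc1NN1C(=O)C=C(C)C1=O` gives 900 nM. Compound 2 `CCOC(=O)c1cnc(-c2cccc(OC)c2)nc1NN1C(=O)C=C(C)C1=O` gives 5000 nM, and the step of a 5.6-fold higher number from compound 1 to compound 2 (0.74 log units; beyond the scatter). Compound 3 `CCOC(=O)c1cnc(-c2ccc(C(F)(F)F)cc2)nc1NN1C(=O)C=C(C)C1=O` gives 400 nM, the lowest of the three numbers; the step of a 2.3-fold lower number from compound 1 to compound 3 (0.35 log units; beyond the scatter) and the step of a 13-fold lower number from compound 2 to compound 3 (1.10 log units; beyond the scatter) both place it beyond the scatter below the other two. Compound 4 `CCOC(=O)c1cnc(C2CC2)nc1NN1C(=O)C=C(C)C1=O` differs from compound 3 in one place: cyclopropyl in place of 4-(trifluoromethyl)phenyl on an aromatic carbon. The two measured steps that end at compound 3 bear on this change, since each alters the group on the same aromatic carbon, yet both keep an aromatic ring there, so neither one tests what happens when that ring is removed altogether. Among the compounds with values here, with no direct precedent, the expectation for compound 4 is a weaker inhibitor than compound 3, with an estimated step of a 6.3-fold higher number from compound 3 to compound 4 (0.80 log units; beyond the scatter). The estimate for compound 4 in this assay is 2500 nM, within a range from 600 nM to 10000 nM.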

Compound 4, half-maximal inhibitory concentration: 1000 nM
The estimate for compound 4 lay 2.5-fold (0.40 log units) above the measured number; the range from low to high includes it.
By their numbers in this assay, from the lowest: compound 3; then compounds 1 and 4 (each within the scatter of the next); then compound 2.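

Compound 4 shows that in this assay an aromatic ring is not required on this carbon between two ring nitrogen atoms: cyclopropyl keeps inhibition in the same range as the aryl groups, with only a modest loss against 4-(trifluoromethyl)phenyl (a 2.5-fold higher number from compound 3 to compound 4 (0.40 log units; beyond the scatter)). Cyclopropyl cannot be told apart from 4-methoxyphenyl (a 1.1-fold higher number from compound 1 to compound 4 (0.05 log units; within the scatter)), and it clearly does better than 3-methoxyphenyl (a 5.0-fold lower number from compound 2 to compound 4 (0.70 log units; beyond the scatter)). An aromatic ring at this position can therefore give a lower or a higher number than cyclopropyl, depending on what the ring carries and where.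

A methyl group, a longer chain such as butyl, or an amine on this carbon would show how far the group can change while inhibition is kept. Nothing available explains why these groups rank as they do.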